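A few compounds are considered here, and "the series" means these few. Any claim that something is new, unique, unknown or untested is made for them only; others in the source may bear on it.

Compound 1, `CCOC(=O)c1cc(-c2ccc(OC(=O)NC3CCCCC3)cc2)n(-c2ccccc2)n1`, is the starting point. In an assay on isolated protein for inhibition of Fatty-acid amide hydrolase 1 (Homo sapiens), read by fluorescence, with a stated time of 30 min (on this read-out lower numbers stand for stronger inhibition and higher numbers for weaker inhibition), compound 1 gives 268 nM. Compound 2, `CCOC(=O)c1cc(-c2ccc(OC(=O)NC3CCCCC3)cc2)n(-c2ccc(Cl)cc2)n1`, differs from compound 1 only by chloro in place of hydrogen on an aromatic carbon, set on an aromatic carbon of a six-membered aromatic ring of carbon only, para to a large group. In this assay compound 2 gives 281 nM, so the step of a 1.0-fold higher number from compound 1 to compound 2 (0.02 log units; within the scatter) leaves the number essentially unchanged. Compound 3, `CCOC(=O)c1cc(-c2cccc(OC(=O)NC3CCCCC3)c2)nn1-c1ccccc1`, is built from the same atoms as compound 1 joined in a different way; the difference between the two cores is not broken down here. In this assay compound 3 gives 539 nM, a number whose gaps to compound 1 and to compound 2 both fall within the usual scatter of repeated measurements, so no ranking among the three can be drawn.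

Compound 4, `CCOC(=O)c1cc(-c2cccc(OC(=O)NC3CCCCC3)c2)nn1-c1ccc(Cl)cc1`, has not yet been measured. It stands to compound 3 exactly as compound 2 stands to compound 1: the change is chloro in place of hydrogen on an aromatic carbon, again para to a large group on a six-membered aromatic ring of carbon only, the same change carried over onto the other core. Among the measured compounds shown here, the step of a 1.0-fold higher number from compound 3 to compound 4 (0.02 log units; within the scatter) is expected to be small, since the single earlier example of this change gave a 1.0-fold higher number from compound 1 to compound 2 (0.02 log units; within the scatter). In this assay, for the measured compounds named here, compound 4 is expected to give about 560 nM, with a likely range from 280 nM to 1100 nM, an estimate resting on only one prior instance of the change.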

Compound 4, half-maximal inhibitory concentration: 353 nM
The estimate for compound 4 lay 1.6-fold (0.20 log units) above the measured number; the range from low to high includes it.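

In this assay, placing chloro on the aromatic ring gives a 1.5-fold lower number from compound 3 to compound 4 (0.18 log units; within the scatter), a step that, like the earlier one, lies within the ordinary spread of repeated measurements. Set side by side, the two steps cannot be told apart, so as far as these data reach, phenyl to 4-chlorophenyl behaves alike on both cores: the same change on two cores in this assay, a 1.0-fold higher number (0.02 log units; within the scatter) from compound 1 to compound 2 and a 1.5-fold lower number (0.18 log units; within the scatter) from compound 3 to compound 4, 1.6-fold (0.20 log units) apart, within the scatter of two such steps. This supports only a modest statement, that no difference between the two cores can be detected for this change; with just two pairs and neither step beyond the scatter, it does not show that chloro alters the number at all, nor that the same result would hold on a further core.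

The compounds shown leave open whether a different group at that same place, such as fluoro, a methoxy group or an amine, would give a step beyond the scatter. From the compounds shown here alone, it also remains open how the number would respond to a change elsewhere in the molecule, for instance a carboxylic acid or a longer chain on a part that stays the same across these pairs.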